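Swapping the Pyridine for a Plain Phenyl Ring

A few compounds are considered here, and "the series" means these few. Any claim that something is new, unique, unknown or untested is made for them only; others in the source may bear on it.

Measured so far in a functional assay on NCI-H460 cells (Homo sapiens) for inhibition, read by sulforhodamine B assay, with a stated time of 48 h; a lower number here means a stronger inhibitor of growth, a higher number a weaker inhibitor of growth:
Compound 1 `COC(=O)c1sc2cc(C#Cc3ccccn3)cnc2c1N`: 34900 nM
Compound 3 `COC(=O)c1sc2cc(C#Cc3cccc(OC)c3)cnc2c1N`: 49000 nM
Compound 2 `COC(=O)c1sc2cc(C#Cc3cccnc3)cnc2c1N`: the assay reports only a limit, > 150000 nM

Compound 1 gives the lowest of the two numbers shown in this assay, and compound 3 sits close by (a 1.4-fold higher number from compound 1 to compound 3 (0.15 log units; within the scatter)). Compound 2, whose result is a limit rather than a number (the limit of > 150000 nM in this assay, at which 1 of the 3 values shown sits), shows a clearly weaker effect (an at least 4.2-fold higher number from compound 1 to compound 2 (0.63 log units; beyond the scatter)). Compound 4 `COC(=O)c1sc2cc(C#Cc3ccccc3)cnc2c1N` differs from compound 1 by phenyl in place of pyridin-2-yl on a triple-bonded carbon. The move to compound 3 is the nearer guide, as it also replaces the pyridin-2-yl and stayed within the scatter; the move to compound 2 warns that a ring change can matter. For compound 4 a small step, a 1.4-fold higher number from compound 1 to compound 4 (0.16 log units; within the scatter), is expected, within the scatter. Compound 4 is estimated at 50000 nM, between 20000 nM and 150000 nM.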

Compound 4, concentration for 50% growth inhibition: > 150000 nM
Compound 4 gave a limit, no number; the forecaster's own chance of this, stated with the estimate: 20%; middle value at least 3.0-fold (0.47 log units) from the limit.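

Replacing pyridin-2-yl with phenyl gives an at least 4.2-fold higher number from compound 1 to compound 4 (0.63 log units; beyond the scatter), so at this triple-bonded carbon a ring nitrogen can count, although compound 2 carries one and still reaches only a limit. Putting hydrogen in place of methoxy gives an at least 3.0-fold higher number from compound 3 to compound 4 (0.48 log units; beyond the scatter), so the bare phenyl ring falls short where the methoxy-bearing ring does not. The result for compound 4 is a limit, shared with compound 2, and the step between these two cannot be read: the limit of > 150000 nM in this assay, at which 2 of the 4 values shown sit.

Still open, going by these compounds, is whether an amine or a carboxylic acid on the phenyl ring, in place of methoxy, would also give a real number in this assay.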